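Sulfonamide series: a fourth aryl sulfonyl variant

The compounds below may be only part of what the source reports. "The series", "measured", "known", "first", "only" and "open" are said of these compounds alone.

Measured so far:
- compound 1 `Cc1ccc(S(=O)(=O)Nc2ccc3oc(-c4ccccc4)nc3c2)cc1`; in an assay on cells for inhibition of HSP60/HSP10 (Homo sapiens), with a stated time of 60 min (on this read-out lower numbers stand for stronger inhibition and higher numbers for weaker inhibition), compound 1 gives > 100000 nM, a limit of the assay.
- compound 2 `C=Cc1ccc(S(=O)(=O)Nc2ccc3oc(-c4ccccc4)nc3c2)cc1`; in this assay compound 2 gives > 100000 nM, likewise a limit.
- compound 3 `O=S(=O)(Nc1ccc2oc(-c3ccccc3)nc2c1)c1ccccc1Cl`; in this assay compound 3 gives > 100000 nM, again a limit.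

Compound 3 thus stands only at a limit, as do the other two, at the limit of > 100000 nM in this assay, at which 3 of the 3 values shown sit. The steps a step that the two limits leave unreadable from compound 1 to compound 2, a step that the two limits leave unreadable from compound 1 to compound 3 and a step that the two limits leave unreadable from compound 2 to compound 3 are all unreadable in size.

Compound 4 `COc1ccc(S(=O)(=O)Nc2ccc3oc(-c4ccccc4)nc3c2)cc1` differs from compound 3 by 4-methoxyphenyl in place of 2-chlorophenyl on a sulfonyl sulfur. Going by the values given here, no measured step bears readably on this change; all three values sit at the limit, so no direction can be taken from them. A step like a step that the limit leaves unreadable from compound 3 to compound 4 is the expectation, with compound 4 likely again at the limit. Compound 4 is estimated at 150000 nM, between 30000 nM and 1000000 nM.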

Compound 4, half-maximal inhibitory concentration: > 100000 nM
Compound 4: no number, only a limit; the forecaster's own chance of this, stated with the estimate: 85%; the middle value lies beyond the limit too.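

Compound 4 also stands at a limit, so no step among compound 1, compound 2, compound 3 and compound 4 can be read: the limit of > 100000 nM in this assay, at which 4 of the 4 values shown sit.

The compounds shown leave open whether any group on the sulfonyl sulfur gives a number in this assay rather than a limit.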